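A Methoxy Group and Stability in Rat Liver Microsomes

The source may report more compounds than this note shows. Statements on the series, on what has been measured and on what is new or still open speak of the compounds shown alone.

Compound 1 `Cc1c(OCCCCOc2cccc(C(=O)O)c2)ccc(C(=O)CC2CCCC2)c1O` was tested in an ADME assay (liver) for metabolic stability, with Liver microsome (Rattus norvegicus) as the target, read by LC-MS, using microsomes and NADPH, with stated times of 5 min and 60 min, tested at 4 uM (on this read-out higher numbers stand for a more stable compound and lower numbers for a less stable compound), where compound 1 gives 55%. Compound 2 `COc1ccc(C(=O)O)cc1OCCCCOc1ccc(C(=O)CC2CCCC2)c(O)c1C` differs from it in a single place, (methoxy in place of hydrogen on an aromatic carbon), and in this assay compound 2 gives 14%. That one change brought a number 41 percentage points lower from compound 1 to compound 2 (beyond the scatter). Compound 3 `Cc1c(OCCCCOc2cccc(C(=O)O)c2)ccc(C(=O)CC(C)C)c1O` rests on a slightly different core; its difference from compound 1 is isopropyl in place of cyclopentyl on a saturated chain carbon bound to a carbonyl carbon, and with that difference came a number 4 percentage points lower from compound 1 to compound 3 (within the scatter). In this assay compound 3 gives 51%. Compound 4 `COc1ccc(C(=O)O)cc1OCCCCOc1ccc(C(=O)CC(C)C)c(O)c1C` has not yet been measured. Among the measured compounds shown here, it differs from compound 3 by methoxy in place of hydrogen on an aromatic carbon, which is the same change, at the same place, as the one leading from compound 1 to compound 2. Because that change produced a number 41 percentage points lower from compound 1 to compound 2 (beyond the scatter), and because the core difference itself produced only a number 4 percentage points lower from compound 1 to compound 3 (within the scatter), a step of a similar size is expected here, namely a number 39 percentage points lower from compound 3 to compound 4 (beyond the scatter). Compound 4 is therefore estimated at 12%, with a likely range from 4% to 26%.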

Compound 4, percent of the compound remaining: 5%
For compound 4 the middle estimate is 7 percentage points above the measured one; the range from low to high includes it.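

In this assay, putting a methoxy group in place of hydrogen on the core of compound 3 gave a number 46 percentage points lower from compound 3 to compound 4 (beyond the scatter), and this large step closely matches the one seen when the same change was made on the core of compound 1: the same change on two cores in this assay, a number 41 percentage points lower (beyond the scatter) from compound 1 to compound 2 and a number 46 percentage points lower (beyond the scatter) from compound 3 to compound 4, 5 percentage points apart, within the scatter of two such steps. The swap of cyclopentyl for isopropyl also carries over once the methoxy group is present, with a number 9 percentage points lower from compound 2 to compound 4 (within the scatter), so it again makes no difference beyond the usual scatter: the same change on two cores in this assay, a number 4 percentage points lower (within the scatter) from compound 1 to compound 3 and a number 9 percentage points lower (within the scatter) from compound 2 to compound 4, 5 percentage points apart, within the scatter of two such steps. This shows that the methoxy step carried over between two closely related cores in this one assay, but two cores are too few to show that it would hold across the wider series, and the numbers do not tell why the compounds with methoxy fare so much worse.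

As far as these compounds go, whether an ethoxy group or a fluorine atom on the same aromatic carbon would bring a step of similar size remains open. From the compounds shown here alone, it is also open whether the methoxy step would hold with an amide in place of the carboxy group, or with a longer chain in place of the present one.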